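This account rests on a few compounds, and the source may have more. Where it says the series, first, only, none or still open, it means among the compounds named here.

Of the compounds shown here, three sharing one core have been measured in an assay on isolated protein for binding affinity to corticotropin-releasing factor receptor 1 (Homo sapiens); a lower number here means a stronger inhibitor, a higher number a weaker inhibitor. Compound 1 `C=CCN(CC=C)c1nc(C)nc(Nc2c(CC)cccc2CC)n1` gives 5700 nM. Compound 3 `CCc1cccc(CC)c1Nc1nc(C)nc(N(CC)Cc2ccccc2)n1` gives 1700 nM. For compound 2 `CCCN(Cc1ccccc1)c1nc(C)nc(Nc2c(CC)cccc2CC)n1` the assay reports only a limit and no number, > 10000 nM. Among the measured compounds shown here, compound 2 is the one member of the set sitting at that limit (the limit of > 10000 nM in this assay, at which 1 of the 3 values shown sits). Compound 4 `CCCN(CC1CC1)c1nc(C)nc(Nc2c(CC)cccc2CC)n1` differs from compound 2 by cyclopropyl in place of phenyl on a saturated chain carbon bound to a nitrogen on an aromatic ring. For the measured compounds named here, no measured step changes this same group, so the outcome is uncertain. The nearest comparison is an at least 5.8-fold lower number from compound 2 to compound 3 (0.76 log units; beyond the scatter), where hydrogen in place of methyl on the saturated chain gave a stronger binder. A step in the same direction is therefore expected, an at least 2.8-fold lower number from compound 2 to compound 4 (0.45 log units; beyond the scatter). Compound 4 is estimated at 3500 nM, between 900 nM and 12000 nM.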

Compound 4, inhibition constant: > 10000 nM
Compound 4 gave a limit, no number; the forecaster's own chance of this, stated with the estimate: 30%; middle value at least 2.8-fold (0.45 log units) from the limit.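

In this assay compound 4 gives only a limit, > 10000 nM, and the step from compound 2 cannot be read, since both ends are limits: the limit of > 10000 nM in this assay, at which 2 of the 4 values shown sit.

So with the propyl chain kept, cyclopropyl in place of phenyl on a saturated chain carbon bound to a nitrogen on an aromatic ring still gives no number. Among the compounds shown here, the one readable step is an at least 1.7-fold higher number from compound 1 to compound 4 (0.24 log units; that floor lies within the scatter), which sets no firm order between (cyclopropylmethyl)(propyl)amino and diallylamino.

Still open, from the compounds shown here alone, is whether cyclopropylmethyl would give a number when paired with the ethyl chain of compound 3, and whether a hydroxyethyl group in place of propyl would.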